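The source may report more compounds than this note shows. Statements on the series, on what has been measured and on what is new or still open speak of the compounds shown alone.

Compound 2 `CO/N=C(\C)c1ccccc1NCC1=NCCN1` is one of two compounds that have been measured in a functional assay for activation of Alpha-1B adrenergic receptor (Homo sapiens), read by calcium flux; on this read-out lower numbers stand for an effect already at smaller amounts and higher numbers for an effect only at larger amounts of compound. Compound 1 `c1cnc(-c2ccccc2NCC2=NCCN2)nc1` gives 77.6 nM in this assay. For compound 2 this assay reports only a limit, < 5020 nM, and not a number. The step that the limit leaves unreadable from compound 1 to compound 2 therefore cannot be sized, since (the limit of < 5020 nM in this assay, at which 1 of the 2 values shown sits). Compound 3 `CC/C(=N/OC)c1ccccc1NCC1=NCCN1` has not been measured; it differs from compound 2 by a group of 6 heavy atoms (4 carbon, 1 nitrogen, 1 oxygen; no ring) in place of a group of 5 heavy atoms (3 carbon, 1 nitrogen, 1 oxygen; no ring), on an aromatic carbon. No measured step traces a change of this kind, and the single step on record runs into the limit, so nothing among the numbers shown argues for movement in either direction. Compound 3 is thus expected to land near where compound 2 stands. The step that the limit leaves unreadable from compound 2 to compound 3 is expected to stay within the usual scatter. The estimate for compound 3 in this assay is 3000 nM, with a range from 500 nM to 10000 nM.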

Compound 3, half-maximal effective concentration: < 5020 nM
Compound 3 ended at the assay's limit (the forecaster's own chance of this, stated with the estimate: 55%); the middle value does not contradict the limit.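

In this assay no new step can be read among compound 1, compound 2 and compound 3, because compound 2 and compound 3 are reported only as limits: the limit of < 5020 nM in this assay, at which 2 of the 3 values shown sit. The compounds shown leave open where the actual values of compound 2 and compound 3 lie, and whether these two differ at all in this assay.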